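The source may report more compounds than this note shows. Statements on the series, on what has been measured and on what is new or still open speak of the compounds shown alone.

Measured to date in a functional assay on HCT-116 cells (Homo sapiens) for inhibition, read by MTT assay, with a stated time of 48 h; on this read-out lower numbers stand for stronger inhibition and higher numbers for weaker inhibition:
compound 1 `Fc1ccccc1CSc1nnc(-c2ccncc2)n1-c1ccccc1` gives 12000 nM
compound 2 `Brc1ccccc1CSc1nnc(-c2ccncc2)n1-c1ccccc1` gives 20200 nM
compound 3 `Brc1ccc(CSc2nnc(-c3ccncc3)n2-c2ccccc2)cc1` gives 11100 nM

The three measured compounds share one core and differ only in the aryl group on a saturated chain carbon bound to a sulfur. Compound 1 stands second highest of the three numbers; its nearest neighbour is compound 3, with a 1.1-fold lower number from compound 1 to compound 3 (0.03 log units; within the scatter), and its furthest is compound 2, with a 1.7-fold higher number from compound 1 to compound 2 (0.23 log units; within the scatter), both within the scatter. The remaining pair shows a 1.8-fold lower number from compound 2 to compound 3 (0.26 log units; within the scatter), again within the scatter. Taken together, the three values are indistinguishable at the usual repeatability.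

Compound 4 `O=[N+]([O-])c1cccc(CSc2nnc(-c3ccncc3)n2-c2ccccc2)c1` is not yet measured. Relative to compound 1 it carries 3-nitrophenyl in place of 2-fluorophenyl on a saturated chain carbon bound to a sulfur.

Every measured step at that carbon, whether bromo in place of fluoro or one aryl group in place of another, stays within the scatter, so the data give no ground for expecting any step beyond it from a further change of the aryl group at the same place. Compound 4 is therefore estimated to give about 12000 nM, with a range from 5000 nM to 30000 nM. The expected step is no change at the digits printed from compound 1 to compound 4 (within the scatter), an estimate resting on the three measured compounds alone.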

Compound 4, half-maximal inhibitory concentration: 19800 nM
Beside the measured number, compound 4's estimate is 1.7-fold (0.22 log units) below it; measured number inside the range.
By their numbers in this assay, from the lowest: compounds 3, 1, 4 and 2 (each within the scatter of the next).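

In this assay, the 3-nitrophenyl group on a saturated chain carbon bound to a sulfur stays within the scatter of each aryl group measured before it, with a 1.7-fold higher number from compound 1 to compound 4 (0.22 log units; within the scatter), a 1.8-fold higher number from compound 3 to compound 4 (0.25 log units; within the scatter) and a 1.0-fold lower number from compound 2 to compound 4 (0.01 log units; within the scatter). The earlier compounds shown here varied only a bromo or fluoro substituent on the phenyl ring, whereas this change brings in a group with neither halogen, 9 heavy atoms in place of the 7 of 2-fluorophenyl, and 2 hydrogen-bond acceptors in place of 0, and still no step at this position goes beyond the scatter. All four compounds therefore remain indistinguishable at the usual repeatability, and nothing measured here offers an explanation for that.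

On these data alone, all four compounds keep a substituted phenyl ring at this place, so it remains open whether an aliphatic amine, a carboxylic acid or a longer alkyl chain there would give a step beyond the scatter. The rest of the shared core is the same throughout, so these compounds say nothing about how changes elsewhere on it would read in this assay.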